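From compound 2 to its hydroxy analogue

A few compounds are considered here, and "the series" means these few. Any claim that something is new, unique, unknown or untested is made for them only; others in the source may bear on it.

Measured in a functional assay on HCT-116 cells (Homo sapiens) for cytotoxicity, read by MTT assay, with a stated time of 3 days; a higher number here means a weaker inhibitor, a lower number a stronger inhibitor:
Compound 1 `CC(C)(C)c1cc2c(N/N=C/c3ccc(CN)cc3)ncnc2s1`: 0.334 ug/mL
Compound 2 `CNCc1ccc(/C=N/Nc2ncnc3sc(C(C)(C)C)cc23)cc1`: 0.056 ug/mL

Compound 2 holds the lower of the two numbers, and the gap lies beyond the scatter. Still unmeasured is compound 3 `CC(C)(C)c1cc2c(N/N=C/c3ccc(O)cc3)ncnc2s1`. The change is hydroxy in place of (methylamino)methyl on an aromatic carbon, para to a large group. For the measured compounds named here, only one measured step bears on this, and only indirectly: a 6.0-fold lower number from compound 1 to compound 2 (0.78 log units; beyond the scatter), with methyl in place of hydrogen on an amine nitrogen. That step shows that the number in this assay moves with a single small edit at this amine. Going by the values given here, compound 3 loses the whole amine-bearing group, and no measured compound lacks it, so uncertainty is wide. A move towards a higher number is expected. The expected size is a 7.1-fold higher number from compound 2 to compound 3 (0.85 log units; beyond the scatter). For compound 3 the estimated value is 0.4 ug/mL, with an expected range of 0.08 ug/mL to 2 ug/mL.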

Compound 3, half-maximal inhibitory concentration: 0.844 ug/mL
Estimate against measurement, compound 3: 2.1-fold (0.32 log units) below, within the range that was stated.
By their numbers in this assay, from the lowest: compound 2; then compound 1; then compound 3.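

In this assay, putting hydroxy in place of (methylamino)methyl on this aromatic carbon gives a 15-fold higher number from compound 2 to compound 3 (1.18 log units; beyond the scatter), so this position responds not only to an edit at the amine nitrogen but also to replacing the whole group. The same direction holds when hydroxy replaces aminomethyl, with a 2.5-fold higher number from compound 1 to compound 3 (0.40 log units; beyond the scatter), and both amine-bearing compounds therefore give lower numbers than compound 3 in this set. No measurement available here accounts for these differences.

The compounds shown leave open whether the nitrogen itself matters, or whether a plain methyl or a methoxy on this aromatic carbon would give a number like that of compound 3. Also open, going by these compounds, is how a dimethylaminomethyl group, or a longer chain carrying the amine, would compare with compound 2.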